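Shifting the amino acid side chain in a benzophenone amide series

The compounds below may be only part of what the source reports. "The series", "measured", "known", "first", "only" and "open" are said of these compounds alone.

Compound 1 `CN(C(=O)CNC(=O)CN1CCCCC1)c1ccc(Cl)cc1C(=O)c1ccccc1Cl`: > 100 mg/kg
Compound 2 `CC(NC(=O)CN)C(=O)N(C)c1ccc(Cl)cc1C(=O)c1ccccc1Cl`: 8.5 mg/kg

The two measured compounds share one core and differ only in the acyl chain on the amide nitrogen. In a functional assay on the whole organism with Mus musculus as the target, in the rotarod test (a higher number here means that more compound is needed for the effect, a lower number that less compound is needed), compound 1 reaches only a limit, > 100 mg/kg, and no number is known for it. In this assay, among the compounds with values here, compound 2 gives 8.5 mg/kg, the one real number among the values shown; the other value sits at the limit of > 100 mg/kg in this assay, at which 1 of the 2 values shown sits. Compound 3 `CN(C)CC(=O)NCC(=O)N(C)c1ccc(Cl)cc1C(=O)c1ccccc1Cl` has not yet been tested. It differs from compound 2 by ((((dimethylamino)methyl)carbonyl)amino)methyl in place of 1-(((aminomethyl)carbonyl)amino)ethyl on a carbonyl carbon. Whether that exchange costs or gains potency is not shown by any measured pair, since no two compounds here differ by this change alone. The step from compound 2 to compound 3 is expected to be a 4.7-fold higher number from compound 2 to compound 3 (0.67 log units; beyond the scatter), towards a larger dose. For compound 3 the estimated value in this assay is 40 mg/kg, with a range from 10 mg/kg to 160 mg/kg.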

Compound 3, dose for half-maximal effect: 26 mg/kg
Estimate against measurement, compound 3: 1.5-fold (0.19 log units) above; the range from low to high includes it.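

In this assay, within the data shown here, putting ((((dimethylamino)methyl)carbonyl)amino)methyl in place of 1-(((aminomethyl)carbonyl)amino)ethyl on a carbonyl carbon gives a 3.1-fold higher number from compound 2 to compound 3 (0.49 log units; beyond the scatter), so the first measured exchange at this place raises the dose needed. Dimethylamino in place of piperidin-1-yl on a saturated chain carbon bound to a carbonyl carbon gives an at least 3.8-fold lower number from compound 1 to compound 3 (0.58 log units; beyond the scatter), which shows that the group at this place alone can shift the dose. Compound 1 has only a limit and not a number, so the full size of that step stays unknown: the limit of > 100 mg/kg in this assay, at which 1 of the 3 values shown sits.

The exchange from compound 2 to compound 3 alters the chain as a whole, so the compounds shown do not separate the effect of the ethyl branch from that of the dimethylamino group. As far as these compounds go, how diethylamino or morpholin-4-yl would compare with dimethylamino also remains open.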